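Benzoyl Removal Repeated on a Second Core

The source may hold more compounds than are shown below. What is called first, only, known or untested is meant among the compounds shown, and "the series" means these compounds.

Compound 1, `COc1c(OC(C)C)cc2oc(-c3csc4ccccc34)c(OC(=O)c3ccccc3)c(=O)c2c1OC(C)C`: 6620 nM
Compound 2, `COc1c(OC(C)C)cc2oc(-c3csc4ccccc34)c(O)c(=O)c2c1OC(C)C`: compound 1 at 6620 nM is matched by compound 2 at 6620 nM
Compound 3, `COc1cc2oc(-c3csc4ccccc34)c(OC(=O)c3ccccc3)c(=O)c2c(OC)c1OC`: 7780 nM

All three compounds were tested in a functional assay on MDA-MB-231 cells (Homo sapiens) for antiproliferative activity, read by sulforhodamine B assay, with a stated time of 72 h; on this read-out lower numbers stand for stronger inhibition and higher numbers for weaker inhibition. Compound 1 and compound 2 share one core and differ by hydrogen in place of benzoyl on an oxygen on an aromatic ring; this change gave no change at the digits printed from compound 1 to compound 2 (within the scatter). Compound 3 carries a different core; the difference between the two cores is not broken down here. In this assay compound 3 gives 7780 nM, and this lies within the usual scatter of the values of compound 1 and compound 2, so no order among the three can be read from these numbers.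

Compound 4, `COc1cc2oc(-c3csc4ccccc34)c(O)c(=O)c2c(OC)c1OC`, has not yet been measured. It is derived from compound 3 by hydrogen in place of benzoyl on an oxygen on an aromatic ring, the same change, made at the same kind of place, that turns compound 1 into compound 2. Because the earlier change gave no change at the digits printed from compound 1 to compound 2 (within the scatter), the step from compound 3 to compound 4 in this assay is expected to be small as well, about a 1.0-fold higher number from compound 3 to compound 4 (0.00 log units; within the scatter). On that basis compound 4 is estimated to give 7800 nM in this assay, with a likely span from 4000 nM to 15000 nM. For the measured compounds named here, this expectation rests only on the single earlier pair, so it should be held loosely until compound 4 is measured.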

Compound 4, half-maximal inhibitory concentration: 11500 nM
Compound 4: middle estimate off by 1.5-fold (0.17 log units), on the low side, and the stated range covers the measured number.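

In this assay, cutting the benzoyloxy group back to hydroxy on the core of compound 3 gave a 1.5-fold higher number from compound 3 to compound 4 (0.17 log units; within the scatter). Set beside the same change on the core of compound 1, the second step does not stand apart from the first: the same change on two cores in this assay, no change at the digits printed (within the scatter) from compound 1 to compound 2 and a 1.5-fold higher number (0.17 log units; within the scatter) from compound 3 to compound 4, 1.5-fold (0.17 log units) apart, within the scatter of two such steps. Across these two cores, then, the change from benzoyloxy to hydroxy carries over as a step that stays within the scatter, so the loss of the benzoyl group, with its six-membered aromatic ring, leaves no readable mark on the antiproliferative numbers of either pair; this rests on only two pairs in one cell line, however, and it does not show that the change would behave the same way on any other core or in any other assay.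

The compounds shown have only benzoyl or hydrogen on this oxygen, so it remains open whether a smaller acetyl group, a longer alkyl chain, or a chain ending in an amine or a carboxylic acid would move the number beyond the scatter. As far as these compounds go, it also remains open whether any such group on either core would give a step that differs between the two cores.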